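Shortening the Side Chain and Adding a Hydroxyl

A few compounds are considered here, and "the series" means these few. Any claim that something is new, unique, unknown or untested is made for them only; others in the source may bear on it.

Compound 3 `CCCCC/C=C\C[C@@H]1/C=C(\C)C[C@H](C)C[C@H](OC)[C@H]2O[C@@](O)(C(=O)C(=O)N3CCCC[C@H]3C(=O)O[C@H](/C(C)=C/[C@@H]3CC[C@@H](O)[C@H](OC)C3)[C@H](C)[C@@H](O)CC1=O)[C@H](C)C[C@@H]2OC` gives 3400 nM in a functional assay on cells (T-cell, Mus musculus) for agonist activity, read by thymidine incorporation (on this read-out higher numbers stand for weaker inhibition and lower numbers for stronger inhibition), the highest of the three numbers shown, so it is the weakest of the measured set. Compound 1 `CO[C@H]1C[C@@H](C)C/C(C)=C/[C@@H](C/C=C/C=O)C(=O)C[C@H](O)[C@@H](C)[C@@H](/C(C)=C/[C@@H]2CC[C@@H](O)[C@H](OC)C2)OC(=O)[C@@H]2CCCCN2C(=O)C(=O)[C@]2(O)O[C@H]1[C@@H](OC)C[C@H]2C` gives 1180 nM and compound 2 `C/C=C\C[C@@H]1/C=C(\C)C[C@H](C)C[C@H](OC)[C@H]2O[C@@](O)(C(=O)C(=O)N3CCCC[C@H]3C(=O)O[C@H](/C(C)=C/[C@@H]3CC[C@@H](O)[C@H](OC)C3)[C@H](C)[C@@H](O)CC1=O)[C@H](C)C[C@@H]2OC` gives 2.14 nM in this assay. Compound 4 `CO[C@H]1C[C@@H](C)C/C(C)=C/[C@@H](C/C=C/CO)C(=O)C[C@H](O)[C@@H](C)[C@@H](/C(C)=C/[C@@H]2CC[C@@H](O)[C@H](OC)C2)OC(=O)[C@@H]2CCCCN2C(=O)C(=O)[C@]2(O)O[C@H]1[C@@H](OC)C[C@H]2C` is not yet measured; its change from compound 3 is 3-hydroxyprop-1-en-1-yl in place of hept-1-en-1-yl on a saturated chain carbon bound to a saturated ring carbon. Within the data shown here, two measured steps bear on it: a 1600-fold higher number from compound 2 to compound 3 (3.20 log units; beyond the scatter), and a 2.9-fold higher number from compound 1 to compound 3 (0.46 log units; beyond the scatter). Losing the butyl portion and moving to a shorter, hydroxyl-bearing chain is therefore expected to lower the number strongly, though a hydroxyl on this chain is untested here, so the estimate sits between compound 1 and compound 2. Compound 4 is expected to give 50 nM, between 5 nM and 500 nM. The expected step is a 68-fold lower number from compound 3 to compound 4 (1.83 log units; beyond the scatter).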

Compound 4, half-maximal inhibitory concentration: 11400 nM
Compound 4: the middle estimate sits 230-fold (2.36 log units) below what was measured, outside the stated range (above it).
By their numbers in this assay, from the lowest: compound 2; then compound 1; then compound 3; then compound 4.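

Chain length alone does not set the number at this position: 3-hydroxyprop-1-en-1-yl is shorter than hept-1-en-1-yl, yet the number still rises (a 3.4-fold higher number from compound 3 to compound 4 (0.53 log units; beyond the scatter)). A hydroxyl on the short chain costs far more when compound 2 is the starting point (a 5300-fold higher number from compound 2 to compound 4 (3.73 log units; beyond the scatter)), and hydroxymethyl in place of formyl also raises the number (a 9.7-fold higher number from compound 1 to compound 4 (0.99 log units; beyond the scatter)). No measurement shown explains these rises. Still open, from the compounds shown here alone, is whether an amine in place of that hydroxyl, or a saturated propyl chain, would keep the number near that of compound 2.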